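Triazine series: chloro in place of amino at compound 4

The compounds below may be only part of what the source reports. "The series", "measured", "known", "first", "only" and "open" are said of these compounds alone.

Measured so far:
- compound 1 `CNc1nc(NC2CCCC2)nc(NC2(C#N)CCCCC2)n1`; in an in vitro assay on Sf21 cells for inhibition of high affinity 3',5'-cyclic-AMP phosphodiesterase 7A (Homo sapiens) (on this read-out higher numbers stand for weaker inhibition and lower numbers for stronger inhibition), compound 1 gives > 5000 nM, which is a limit of the assay and not a number
- compound 2 `CNc1nc(NC2(C#N)CCCCC2)nc(N(C)C)n1`; in this assay compound 2 gives > 5000 nM, again a limit of the assay
- compound 3 `CNc1nc(N)nc(NC2(C#N)CCCCC2)n1`; in this assay compound 3 gives "not determined" (no result reported)

Compound 3 therefore stands without a single number: the two further values in the series are both limits, and nothing places compound 3 relative to them.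

The step to compound 4 `CNc1nc(Cl)nc(NC2(C#N)CCCCC2)n1` is chloro in place of amino on an aromatic carbon.

Going by the values given here, only one measured step exists, a step that the two limits leave unreadable from compound 1 to compound 2, and its size cannot be read because both of its ends sit at the limit of > 5000 nM in this assay, at which 2 of the 3 values shown sit. It concerns a different place on the shared core and gives no size to carry over. No direction or size beyond the scatter can thus be expected for the step from compound 3 to compound 4 in this assay; the estimate is given alone.

Compound 4 is expected at 5000 nM, with a range from 1000 nM to 20000 nM, and a considerable chance that only a limit is reported.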

Compound 4, half-maximal inhibitory concentration: 1070 nM
The estimate for compound 4 lay 4.7-fold (0.67 log units) above the measured number; measured number inside the range.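

In this assay, going by these compounds alone, chloro at this position, opposite the ring nitrogen, gives the only number so far, with an at least 4.6-fold lower number from compound 2 to compound 4 (0.66 log units; beyond the scatter) for chloro in place of dimethylamino and an at least 4.6-fold lower number from compound 1 to compound 4 (0.66 log units; beyond the scatter) for chloro in place of cyclopentylamino. Both steps give only a minimum size, as each starts from a limit of the assay: the limit of > 5000 nM in this assay, at which 2 of the 4 values shown sit. Chloro at this position therefore separates compound 4 from compound 1 and compound 2 beyond the scatter, while the steps from compound 1 to compound 2 and from compound 3 to compound 4 cannot be read.

The compounds shown leave open whether chloro itself matters or only the loss of the amino groups, which a methyl, methoxy or fluoro group at this position would help to separate. Also open, as far as these compounds go, is what a change to the methylamino group does while chloro stays in place.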